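The compounds below may be only part of what the source reports. "The series", "measured", "known", "first", "only" and "open" are said of these compounds alone.

Compound 2 `CC(C)CCN(CCC(C)C)c1cccc(C(=O)N2CCc3ccc(OS(N)(=O)=O)cc3C2)c1` stands highest of the two numbers in an assay on HEK293 cells for inhibition of Steryl-sulfatase (Homo sapiens), tested at 1 uM (a higher number here means a stronger effect of the compound at the concentration tested, a lower number a weaker effect), where compound 2 gives 75.9%. Its only comparator, compound 1 `NS(=O)(=O)Oc1ccc2c(c1)CN(C(=O)c1cccc(N3CCCCC3)c1)CC2`, gives 11.9% in this assay. Compound 3 `CCCN(Cc1ccccc1)c1cccc(C(=O)N2CCc3ccc(OS(N)(=O)=O)cc3C2)c1` differs from compound 2 at a single place: benzyl(propyl)amino in place of diisopentylamino on an aromatic carbon. Among the compounds with values here, the one step measured so far bears on this change only loosely: a number 64 percentage points higher from compound 1 to compound 2 (beyond the scatter), a large rise that came from putting diisopentylamino in place of piperidin-1-yl. Benzyl(propyl)amino is, like diisopentylamino, an amine carrying two open chains rather than a closed ring, so much of that gain is expected to be kept, but the aromatic ring it brings has no counterpart among the measured compounds, and the uncertainty is wide. Compound 3 is therefore expected to give 62% in this assay, somewhere between 30% and 85%. The expected step is a number 13.9 percentage points lower from compound 2 to compound 3 (beyond the scatter), a modest fall that may well lie within the scatter.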

Compound 3, a percentage reported as inhibition, at one concentration (the size of the read-out at that concentration, not a potency): 67.4%
Compound 3: middle estimate off by 5.4 percentage points, on the low side; low and high end bracket the measured number.
By their numbers in this assay, from the lowest: compound 1; then compounds 3 and 2 (each within the scatter of the next).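

In this assay, exchanging the two amines gives a number 8.5 percentage points lower from compound 2 to compound 3 (within the scatter) and so does not separate them, even though benzyl(propyl)amino brings a six-membered aromatic ring of carbon only and diisopentylamino has no ring. The result also gives a number 55.5 percentage points higher from compound 1 to compound 3 (beyond the scatter) and shows that the high read-out of compound 2 is not unique to diisopentylamino: on this aromatic carbon, two different amines with separate substituents on nitrogen both stand well clear of piperidin-1-yl. No measurement shown explains this difference or why the two amines read alike.

Still open, as far as these compounds go, is whether dibenzylamino or diethylamino would hold this level, and whether a different closed ring, such as morpholin-4-yl, would read as low as compound 1. A read-out at a single concentration also leaves the potencies of compound 2 and compound 3 undefined.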